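The compounds below may be only part of what the source reports. "The series", "measured", "known", "first", "only" and "open" are said of these compounds alone.

Compound 3 `N#C/C(=C\c1ccccc1OS(=O)(=O)c1ccc(F)cc1)C(=O)Nc1nnc(Cc2cccc3ccccc23)s1` stands second highest of three numbers in a functional assay on RS4-11 cells (Homo sapiens) for inhibition, read by CCK-8 assay, with a stated time of 48 h, tested at 20 uM (a lower number here means less inhibition of growth, a higher number more inhibition of growth at the concentration tested), where compound 3 gives 68%. Compound 1 `COc1ccc(S(=O)(=O)Oc2ccccc2/C=C(\C#N)C(=O)Nc2nnc(Cc3cccc4ccccc34)s2)cc1` gives 78% and compound 2 `N#C/C(=C\c1ccccc1OS(=O)(=O)c1ccc([N+](=O)[O-])cc1)C(=O)Nc1nnc(Cc2cccc3ccccc23)s1` gives 58%. Between them, a number 10 percentage points lower from compound 1 to compound 3 (within the scatter) and a number 10 percentage points higher from compound 2 to compound 3 (within the scatter), while a number 20 percentage points lower from compound 1 to compound 2 (beyond the scatter). Compound 4 `Cc1ccc(Cc2nnc(NC(=O)/C(C#N)=C/c3ccccc3OS(=O)(=O)c3ccc(F)cc3)s2)cc1` differs from compound 3 elsewhere on the shared core: 4-methylphenyl in place of naphthalen-1-yl on a saturated chain carbon bound to an aromatic carbon. None of the three measured steps bears on this part of the molecule; all of them exchange the group on the aromatic carbon carrying methoxy, nitro or fluoro, and all were modest or within the scatter. For compound 4 the expected step is therefore uncertain, set as a number 13 percentage points lower from compound 3 to compound 4 (beyond the scatter) with a wide range. Compound 4 is estimated at 55%, between 30% and 80%.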

Compound 4, percent growth inhibition at one concentration: 73%
The estimate for compound 4 lay 18 percentage points below the measured number; the measured number falls inside the stated range.
By their numbers in this assay, from the lowest: compounds 2, 3, 4 and 1 (each within the scatter of the next, the first and the last beyond it).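

In this assay, going by these compounds alone, the group on the saturated chain carbon is varied for the first time, and a number 5 percentage points higher from compound 3 to compound 4 (within the scatter) when 4-methylphenyl replaces naphthalen-1-yl. This position therefore tolerates the loss of one six-membered aromatic ring, at a single tested concentration and in this one pair, with fewer heavy atoms in the entering group than in the group it replaces. No supporting data explain this result. 

The compounds shown leave open how an amine or a carboxylic acid at this position would read. They also leave open whether 4-methylphenyl behaves the same way alongside methoxy or nitro in place of fluoro.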